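The compounds below may be only part of what the source reports. "The series", "measured", "known", "first", "only" and "open" are said of these compounds alone.

Compound 1, with the structure `Nc1ncnc2c1c(-c1cnc3[nH]ccc3c1)nn2CCCC(=O)NO`, was tested in a functional assay on HepG2 cells (Homo sapiens) for inhibition, read by MTT assay, with a stated time of 72 h; on this read-out lower numbers stand for stronger inhibition and higher numbers for weaker inhibition. In this assay compound 1 gives > 50000 nM, which is a limit of the assay rather than a measured number. Two related compounds carry the same hydroxycarbamoyl group on a chain: compound 2, `Nc1nc2cc(-c3nn(CC(=O)NO)c4ncnc(N)c34)ccc2o1`, and compound 3, `Nc1nc2cc(-c3nn(CCC(=O)NO)c4ncnc(N)c34)ccc2o1`. In this assay compound 2 gives > 150000 nM, again only a limit. In this assay compound 3 gives > 150000 nM, also a limit. The step that the two limits leave unreadable from compound 2 to compound 3 therefore cannot be read. Compound 1 thus stands at the limit of > 50000 nM in this assay, at which 1 of the 3 values shown sits, while the two other values sit at the limit of > 150000 nM in this assay, at which 2 of the 3 values shown sit. Compound 4, `Nc1ncnc2c1c(-c1cnc3[nH]ccc3c1)nn2CCCCC(=O)NO`, differs from compound 1 by (hydroxycarbamoyl)methyl in place of hydroxycarbamoyl on a saturated chain carbon, three bonds along the chain from an aromatic nitrogen. The only measured step of the same kind is a step that the two limits leave unreadable from compound 2 to compound 3, which gives no readable size, so neither direction nor size can be drawn for this assay from the numbers shown. The expected step is a step that the limit leaves unreadable from compound 1 to compound 4, with the result most likely sitting again at a limit. Compound 4 is therefore estimated at 100000 nM, within 30000 nM to 300000 nM.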

Compound 4, half-maximal inhibitory concentration: 36700 nM
Compound 4: the middle estimate sits 2.7-fold (0.44 log units) above what was measured; measured number inside the range.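

In this assay compound 4 gives 36700 nM, the first actual number among the compounds shown, and it comes with 4-(hydroxycarbamoyl)butyl in place of 3-(hydroxycarbamoyl)propyl. The change amounts to an at least 1.3-fold lower number from compound 1 to compound 4 (0.13 log units; that floor lies within the scatter), so a real shift in strength is not established. This step is only a floor because compound 1 carries a limit rather than a number: the limit of > 50000 nM in this assay, at which 1 of the 4 values shown sits.

On these data alone, the step from compound 2 to compound 3 cannot be read, so it remains unknown whether the same chain change has any effect on that other core. Also open, as far as these compounds go, is whether a longer chain, such as 5-(hydroxycarbamoyl)pentyl, or a carboxylic acid in place of the hydroxycarbamoyl end would move the number further.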